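The source may report more compounds than this note shows. Statements on the series, on what has been measured and on what is new or still open speak of the compounds shown alone.

Of the compounds shown here, two have been measured in a functional assay on cells (Cancer cell lines, Homo sapiens) for inhibition; on this read-out lower numbers stand for stronger inhibition of growth and higher numbers for weaker inhibition of growth. Compound 1 `COc1ccc(-c2nc3sc(Cc4ccccc4)nn3c2SC#N)cc1` gives 5600 nM. Compound 2 `O=Cc1c(-c2ccc(Br)cc2)nc2sc(Cc3ccccc3)nn12` gives 4200 nM, the lower of the two numbers, though its gap to compound 1 lies within the usual scatter of this assay. Compound 3 `O=Cc1c(-c2ccc([N+](=O)[O-])cc2)nc2sc(Cc3ccccc3)nn12` has not yet been measured; it differs from compound 2 by nitro in place of bromo on an aromatic carbon. Among the compounds with values here, no measured pair shows what this change does, so no step beyond the scatter is expected in either direction. Compound 3 is expected to give about 4000 nM, with a likely range from 1500 nM to 12000 nM. The expected step is a 1.1-fold lower number from compound 2 to compound 3 (0.02 log units; within the scatter).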

Compound 3, concentration for 50% growth inhibition: 4100 nM
Estimate against measurement, compound 3: 1.0-fold (0.01 log units) below; low and high end bracket the measured number.
By their numbers in this assay, from the lowest: compounds 3, 2 and 1 (each within the scatter of the next).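

In this assay, replacing bromo with nitro on this aromatic carbon, para to a large group, gives a 1.0-fold lower number from compound 2 to compound 3 (0.01 log units; within the scatter). Within the data shown here, this is the first direct comparison at this position, and the read-out does not tell the two groups apart, even though nitro brings hydrogen-bond acceptors that bromo lacks. Nothing available explains this result.

Going by these compounds, whether an amine or a carboxylic acid on this carbon would shift the number remains open. So does the contribution of the benzyl group on the shared core.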